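This account rests on a few compounds, and the source may have more. Where it says the series, first, only, none or still open, it means among the compounds named here.

Measured so far:
- compound 1 `Nc1c(C(=O)O)sc2nc(-c3cccs3)cc(-c3ccccc3)c12`: > 7500 nM
- compound 2 `CCC[S+]([O-])c1sc2nc(-c3cccs3)cc(C(=O)N(C)C)c2c1N`: 14.7 nM

Compound 1 was tested in an assay for inhibition of 15-hydroxyprostaglandin dehydrogenase [NAD(+)] (Homo sapiens), read by fluorescence, with a stated time of 15 min, in the presence of a further agent that is not named here (on this read-out higher numbers stand for weaker inhibition and lower numbers for stronger inhibition), and the result is only a limit, > 7500 nM, so no number is known for it. Among the compounds with values here, compound 2 gives 14.7 nM in this assay, but it differs from compound 1 in more than one place, so the two values show only that compound 2 sits far to the strong side while compound 1 sits at the limit of > 7500 nM in this assay, at which 1 of the 2 values shown sits, and no single change can be read out of that pair.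

Compound 3 `CCCCC(=O)c1sc2nc(-c3cccs3)cc(-c3ccccc3)c2c1N` has not been measured. It differs from compound 1 by butyl in place of hydroxy on a carbonyl carbon; the same change, cut one bond further out, reads carboxy to butylcarbonyl. Because compound 1 sits at the limit of > 7500 nM in this assay, at which 1 of the 2 values shown sits, any real number for compound 3 would stand on the stronger side of that limit. The step from compound 1 to compound 3 is expected to be toward stronger inhibition, about an at least 15-fold lower number from compound 1 to compound 3 (1.17 log units; beyond the scatter). For compound 3 the estimate in this assay is 500 nM, with a range from 50 nM to 5000 nM.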

Compound 3, half-maximal inhibitory concentration: > 7500 nM
Compound 3: no number, only a limit; the forecaster's own chance of this, stated with the estimate: 25%; at least 15-fold (1.17 log units) between middle value and limit.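

Compound 1 and compound 3 each give only a limit and not a number, so no step from compound 1 to compound 3 can be read: the limit of > 7500 nM in this assay, at which 2 of the 3 values shown sit.

The compounds shown leave open whether butyl in place of hydroxy on a carbonyl carbon changes inhibition at all, and which of the several differences from compound 2 goes with its stronger inhibition.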